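Two Chalcogen Ethers on Fused Bicyclic Cores, and a Methyl Analogue

The compounds below may be only part of what the source reports. "The series", "measured", "known", "first", "only" and "open" are said of these compounds alone.

Measured compounds:
compound 1, `CCCCCSc1nc(NCc2ccc([Se]C)cc2)c2ccccc2n1`, gives 50000 nM in a functional assay on HTB-54 cells (Homo sapiens) for cytotoxicity, read by MTT assay, with a stated time of 72 h; on this read-out lower numbers stand for stronger inhibition of growth and higher numbers for weaker inhibition of growth
compound 2, `CSc1nc(NCc2ccc([Se]C)cc2)c2ccccc2n1`, gives > 100000 nM in this assay, which is a limit of the assay and not a number
compound 3, `CCCCC[Se]c1nc(N)c2cccnc2n1`, gives 51000 nM in this assay

Compound 1 and compound 2 share a core and differ only by hydrogen in place of butyl on a saturated chain carbon bound to a sulfur. That shortening of the chain made an at least 2.0-fold higher number from compound 1 to compound 2 (0.30 log units; that floor lies within the scatter); the floor of that step lies within the scatter, so the pair says only that the shorter chain does not bring a lower number. For compound 2 the reported value is a limit of > 100000 nM in this assay, at which 1 of the 3 values shown sits, rather than a measured number.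

Compound 3 has a different core, and the difference between the two cores is not broken down here. Compound 3 and compound 1 give values within the scatter of each other, so no order can be read between them.

Compound 4, `C[Se]c1nc(N)c2cccnc2n1`, is not yet measured. It differs from compound 3 by hydrogen in place of butyl on a saturated chain carbon bound to a selenium atom. This is the same kind of change as from compound 1 to compound 2, but not the same: there the place is bound to a sulfur, here it is bound to a selenium atom.

The expectation for compound 4 rests on compound 3 with its 51000 nM and on the step of an at least 2.0-fold higher number from compound 1 to compound 2 (0.30 log units; that floor lies within the scatter) seen with the sulfur pair. Compound 4 is therefore expected to show a 2.0-fold higher number from compound 3 to compound 4 (0.29 log units; within the scatter) in this assay. The estimate for compound 4 in this assay is 100000 nM, with a range from 50000 nM to 200000 nM, and a real chance that only a limit is reported.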

Compound 4, concentration for total growth inhibition: > 100000 nM
Compound 4 gave a limit, no number; the forecaster's own chance of this, stated with the estimate: 60%; the middle value sits exactly at the limit.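

Compound 4 gives > 100000 nM in this assay, and that is a limit of the assay, not a number. Replacing the pentyl chain with methyl, which means hydrogen in place of butyl on a saturated chain carbon bound to a selenium atom, gives an at least 1.9-fold higher number from compound 3 to compound 4 (0.29 log units; that floor lies within the scatter), so here too the shorter chain does not bring a lower number, although the floor of the step lies within the scatter. The change therefore carries from one core to the other only in that direction, and the data do not show that it has the same size on both cores, nor that the sulfur and the selenium atom behave alike at this place: the same change on two cores in this assay, an at least 2.0-fold higher number (0.30 log units; that floor lies within the scatter) from compound 1 to compound 2 and an at least 1.9-fold higher number (0.29 log units; that floor lies within the scatter) from compound 3 to compound 4; the limit leaves it open whether they differ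

With compound 2 and compound 4 both at the limit, the compounds shown do not tell how far the number climbs once the chain is cut, or whether a propyl chain or a longer chain such as octyl would give a lower number than pentyl on either core. Also open, on these data alone, is how a chain carrying an amine or a carboxylic acid would read in this assay, and what swapping only the sulfur for selenium would do on one and the same core.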